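A Dimethylamino Chain in Place of Hydroxyethyl

The source may hold more compounds than are shown below. What is called first, only, known or untested is meant among the compounds shown, and "the series" means these compounds.

Measured in a functional assay on A549 cells (Homo sapiens) for antiproliferative activity, read by MTT assay, with a stated time of 48 h; on this read-out higher numbers stand for weaker inhibition and lower numbers for stronger inhibition:
- compound 1 `CCN(CC)CCn1c(N)c(-c2nc3ccccc3[nH]2)c2nc(C#N)c(C#N)nc21`: > 50000 nM (a limit)
- compound 2 `CCCn1c(N)c(-c2nc3ccccc3[nH]2)c2nc(C#N)c(C#N)nc21`: 1970 nM
- compound 3 `N#Cc1nc2c(-c3nc4ccccc4[nH]3)c(N)n(CCO)c2nc1C#N`: > 50000 nM (a limit)

Compound 3 stands at > 50000 nM, which is a limit of the assay and not a number. That places it at the limit of > 50000 nM in this assay, at which 2 of the 3 values shown sit.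

Compound 4 `CN(C)CCCn1c(N)c(-c2nc3ccccc3[nH]2)c2nc(C#N)c(C#N)nc21` differs from compound 3 by (dimethylamino)methyl in place of hydroxy on a saturated chain carbon, two bonds along the chain from an aromatic nitrogen. In words, this is (dimethylamino)methyl in place of hydroxy on a saturated chain carbon, two bonds along the chain from an aromatic nitrogen.

Among the compounds with values here, no measured step covers this change directly, but three bear on it. The data show an at least 25-fold lower number from compound 1 to compound 2 (1.40 log units; beyond the scatter), and also an at least 25-fold higher number from compound 2 to compound 3 (1.40 log units; beyond the scatter). The third, a step that the two limits leave unreadable from compound 1 to compound 3, tells nothing about size. Among these three compounds, only the one with the plain propyl chain gives a number. The chain of compound 4 carries dimethylamino, much as the chain of compound 1 carries diethylamino, so the large gain seen in an at least 25-fold lower number from compound 1 to compound 2 (1.40 log units; beyond the scatter) is not expected to carry over.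

The estimate is an at least 2.0-fold lower number from compound 3 to compound 4 (0.30 log units; that floor lies within the scatter), an expected small move to a lower number at best, and a reading at the same limit remains likely. Compound 4 is expected at about 25000 nM, with an estimated range of 4000 nM to 80000 nM.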

Compound 4, half-maximal inhibitory concentration: 10400 nM
Compound 4: the middle estimate sits 2.4-fold (0.38 log units) above what was measured, and the stated range covers the measured number.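

In this assay the 3-(dimethylamino)propyl chain of compound 4 gives a number where the 2-hydroxyethyl chain does not, with an at least 4.8-fold lower number from compound 3 to compound 4 (0.68 log units; beyond the scatter) as the step; compound 3 itself remains a limit of the assay and not a number: the limit of > 50000 nM in this assay, at which 2 of the 4 values shown sit. An amine on the chain therefore does not by itself push the reading to that limit, as an at least 4.8-fold lower number from compound 1 to compound 4 (0.68 log units; beyond the scatter) shows alongside the limit held by compound 1, so the amine chains of the two compounds do not read alike. The amine still costs activity against the plain propyl chain, with a 5.3-fold higher number from compound 2 to compound 4 (0.72 log units; beyond the scatter) on adding dimethylamino, and compound 2 remains the strongest of the four.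

The step between compound 1 and compound 4 changes the amine and the chain length together, so the compounds shown cannot separate the two, and a 2-(dimethylamino)ethyl or a 3-(diethylamino)propyl chain would be needed to do so. They also leave open how a 3-hydroxypropyl chain, or a carboxylic acid on the chain, would read.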